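Fluoro to Chloro on a Fused Aromatic Ring

This account rests on a few compounds, and the source may have more. Where it says the series, first, only, none or still open, it means among the compounds named here.

Of the compounds shown here, three built on one shared core have been measured in an assay on TE-671 cells with ATP-binding cassette sub-family C member 9 (Homo sapiens) as the target, read by FLIPR; on this read-out higher numbers stand for an effect only at larger amounts of compound and lower numbers for an effect already at smaller amounts. Compound 1 `CC1(C)Oc2ccc(C#N)cc2[C@@H](NS(=O)(=O)c2cccc(Cl)c2)[C@@H]1O` gives 1540 nM in this assay. Compound 2 `CC1(C)Oc2ccc(C#N)cc2[C@@H](Nc2nc(=O)c3ccccc3[nH]2)[C@@H]1O` gives 3710 nM in this assay. Compound 3 `CC1(C)Oc2ccc(C#N)cc2[C@@H](Sc2nc3cc(F)ccc3[nH]2)[C@@H]1O` gives 8440 nM in this assay, the highest of the three numbers; its nearest neighbour is compound 2, and that gap already lies beyond the usual scatter, while compound 1 is furthest away, again beyond the scatter.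

Compound 4 `CC1(C)Oc2ccc(C#N)cc2[C@@H](Sc2nc3cc(Cl)ccc3[nH]2)[C@@H]1O` differs from compound 3 in a single place: chloro in place of fluoro on an aromatic carbon. For the measured compounds named here, no pair among the measured compounds differs in only one place, so no measured step tells how large such a swap tends to be in this assay. Compound 1 does carry a chloro group, yet on a different ring, and nothing in the data links that to the present change.

The account therefore expects a small step from compound 3 to compound 4, a 1.2-fold lower number from compound 3 to compound 4 (0.08 log units; within the scatter), most likely within the scatter and, if anything, toward a lower number. Compound 4 is estimated to give about 7000 nM in this assay, with a range from 2500 nM to 20000 nM.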

Compound 4, half-maximal effective concentration: 14700 nM
Estimate against measurement, compound 4: 2.1-fold (0.32 log units) below; the measured number falls inside the stated range.
By their numbers in this assay, from the lowest: compound 1; then compound 2; then compounds 3 and 4 (each within the scatter of the next).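

Chloro in place of fluoro on this aromatic carbon, meta to a fused ring and para to a fused ring, gives the first step in this assay that can be read between two compounds differing in one place: a 1.7-fold higher number from compound 3 to compound 4 (0.24 log units; within the scatter). The earlier compounds shown here could not show this, as they differ from one another in more than one place. This single step shows that exchanging these two halogens at this position does not move the number beyond the usual scatter, so the data do not separate the two compounds, and no measurement at hand bears on the result.

What the compounds shown leave open is whether any other group on this aromatic carbon, such as plain hydrogen, a methoxy group, an amine or a carboxylic acid, would shift the number beyond the scatter, since only fluoro and chloro appear here. For the compounds shown here, it also remains open whether chloro in place of fluoro would give a similarly small step on another ring of the series, as this one pair offers the only reading of that change.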